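Swapping 4-chlorophenyl for methoxycarbonyl on a weak compound

The source may hold more compounds than are shown below. What is called first, only, known or untested is meant among the compounds shown, and "the series" means these compounds.

Compound 1 `CC1CCN(C2CCN(S(=O)(=O)c3ccc(-c4ccc(Cl)cc4)cc3)CC2)CC1` stands at the weak end of the scale in an ADME assay on HCT-116 cells (Homo sapiens) for cytotoxicity, read by CellTiter-Glo, with a stated time of 72 h (on this read-out lower numbers stand for stronger inhibition and higher numbers for weaker inhibition), where compound 1 gives > 5000 nM as a limit of the measurement and not as a number. Compound 2 `CC1CCN(C2CCN(S(=O)(=O)c3cc(Br)cc4c3OCC4)CC2)CC1` gives > 10000 nM in this assay and this too is only a limit. Compound 3 `COC(=O)c1ccc(S(=O)(=O)N2CCC(N3CCC(C)CC3)CC2)cc1` has not been measured yet. It carries methoxycarbonyl in place of 4-chlorophenyl on an aromatic carbon, para to a large group (methoxycarbonyl in place of 4-chlorophenyl on an aromatic carbon). The expected change a step that the limit leaves unreadable from compound 1 to compound 3 is small, towards weaker inhibition if anything, and probably no larger than the usual scatter. That expectation rests on compound 1 showing only the limit > 5000 nM as its result, which offers no sign of real potency to build on. Compound 3 is estimated at about 8000 nM with an expected range from 3000 nM to 20000 nM and a limit instead of a number is likely.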

Compound 3, half-maximal inhibitory concentration: > 5000 nM
Compound 3: no number, only a limit; the forecaster's own chance of this, stated with the estimate: 85%; the middle value is on the limit's open side.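

Within the data shown here, compound 1 and compound 3 both give only a limit and not a number, so no step between them can be read. The compounds shown leave open how far methoxycarbonyl in place of 4-chlorophenyl shifts the result in this assay, and whether any of these compounds has a measurable value there.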